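Ethyl for Fluoro at the Amide Aryl Ring

A few compounds are considered here, and "the series" means these few. Any claim that something is new, unique, unknown or untested is made for them only; others in the source may bear on it.

Compound 1, `O=C(CSc1nc(Nc2ccccc2)c2ccccc2n1)Nc1ccccc1F`, gives 9350 nM in a functional assay on NCI-H1975 cells (Homo sapiens) for inhibition, read by MTT assay, with a stated time of 72 h; on this read-out higher numbers stand for weaker inhibition and lower numbers for stronger inhibition.
Compound 2, `O=C(CSc1nc(Nc2ccccc2)c2ccccc2n1)Nc1cccc(F)c1`, gives 6790 nM in this assay.
Compound 3, `O=C(CSc1nc(Nc2ccccc2)c2ccccc2n1)Nc1ccc(F)cc1`, gives 16500 nM in this assay.

Compound 3 carries the highest of the three numbers, although its distance to compound 1, a 1.8-fold higher number from compound 1 to compound 3 (0.25 log units; within the scatter), stays inside the scatter; only its distance to compound 2, a 2.4-fold higher number from compound 2 to compound 3 (0.39 log units; beyond the scatter), goes beyond it. The untested compound 4, `CCc1ccc(NC(=O)CSc2nc(Nc3ccccc3)c3ccccc3n2)cc1`, differs from compound 3 by ethyl in place of fluoro on an aromatic carbon. For the measured compounds named here, none of the measured steps exchanges the fluoro for another group: all three, the third being a 1.4-fold lower number from compound 1 to compound 2 (0.14 log units; within the scatter), merely move the fluoro around the ring, and they stay within or only modestly beyond the scatter. A change of the group itself therefore has no close precedent among these compounds, and the shared core with its fluoro relocations gives little reason to expect a large shift. The account expects for compound 4 in this assay a step of a 1.4-fold lower number from compound 3 to compound 4 (0.14 log units; within the scatter), nothing the scatter would not cover. Compound 4 is estimated at 12000 nM, between 4000 nM and 40000 nM.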

Compound 4, half-maximal inhibitory concentration: 9910 nM
Compound 4: middle estimate off by 1.2-fold (0.08 log units), on the high side; measured number inside the range.
By their numbers in this assay, from the lowest: compounds 2, 1, 4 and 3 (each within the scatter of the next, the first and the last beyond it).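

For the compounds shown here, this is the first exchange of the group itself at this position rather than a move of the fluoro around the ring, and in this assay the step from fluoro to ethyl (a 1.7-fold lower number from compound 3 to compound 4 (0.22 log units; within the scatter)) stays inside the scatter, although one heavy atom gives way to two. The comparisons with the other two fluoro compounds (a 1.5-fold higher number from compound 2 to compound 4 (0.16 log units; within the scatter)) and (a 1.1-fold higher number from compound 1 to compound 4 (0.03 log units; within the scatter)) stay inside it as well, so the 4-ethylphenyl compound cannot be told apart from any of the three fluoro compounds on this read-out. Nothing at hand bears on why the number holds so steady through this change.

On these data alone, whether an amine, a carboxylic acid or a longer chain at this position would carry the number beyond the scatter remains open. So does whether an ethyl would read the same in the places the fluoro takes in compound 1 and compound 2.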